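The source may report more compounds than this note shows. Statements on the series, on what has been measured and on what is new or still open speak of the compounds shown alone.

Working notes on the series. In an ADME assay on CCD 19Lu cells (Homo sapiens) for antiproliferative activity, read by MTT assay, with a stated time of 24 h (a lower number here means a stronger inhibitor, a higher number a weaker inhibitor), compound 3 `Brc1ccc2nc(C3CCCCC3)cc(-c3ccccc3)c2c1` gives 490000 nM, the lower of the two numbers recorded, and compound 1 `COc1ccc2nc(-c3ccccc3)cc(-c3ccccc3)c2c1` gives 925000 nM; the gap between these two lies within the usual scatter, so neither is read as the stronger. For compound 2 `O=[N+]([O-])c1cccc(-c2cc(-c3ccccc3)c3cc(Br)ccc3n2)c1` the entry in this assay is "not determined" (no result reported), so no number is available for it. Compound 4 `Oc1ccc(-c2cc(-c3ccccc3)c3cc(Br)ccc3n2)cc1` differs from compound 3 by 4-hydroxyphenyl in place of cyclohexyl on an aromatic carbon. For the measured compounds named here, no step between measured compounds covers this change, and the two numbers available give no direction to build on, so the change is expected to move this assay by no more than the scatter, in either direction. Compound 4 is therefore estimated at 600000 nM, in the range 200000 nM to 1800000 nM. The expected step is a 1.2-fold higher number from compound 3 to compound 4 (0.09 log units; within the scatter).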

Compound 4, half-maximal inhibitory concentration: 104000 nM
The estimate for compound 4 lay 5.8-fold (0.76 log units) above the measured number, and the stated range ends above it.
By their numbers in this assay, from the lowest: compound 4; then compounds 3 and 1 (each within the scatter of the next).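

At the aromatic carbon next to the ring nitrogen, 4-hydroxyphenyl in place of cyclohexyl gives a 4.7-fold lower number from compound 3 to compound 4 (0.67 log units; beyond the scatter) in this assay. For the compounds shown here, this is the first single change to move this assay beyond the scatter, and it shows that the group at this position can alter the number. No measurement bearing on the reason for this step is available.

As far as these compounds go, whether the lower number follows from the aromatic ring or from its hydroxyl stays open. Also open, from the compounds shown here alone, is how an amine or a carboxylic acid in place of that hydroxyl would read.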